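From Nitrile to Sulfonamide: What Compound 4 May Show

The source may report more compounds than this note shows. Statements on the series, on what has been measured and on what is new or still open speak of the compounds shown alone.

Of the compounds shown here, three have been measured in a functional assay for antagonist activity at transient receptor potential cation channel subfamily V member 1 (Rattus norvegicus); a higher number here means a weaker inhibitor, a lower number a stronger inhibitor. Compound 1 `C[C@@H]1CN(c2ncccc2C(F)(F)F)CCN1C(=O)Nc1ccc(C(F)(F)F)cc1` gives 11 nM. Compound 2 `CC(C)(C)c1ccc(NC(=O)c2ccc(-c3ncccc3F)cc2)cc1` gives 1 nM, and compound 3 `CC(C)(C)c1ccc(NC(=O)c2ccc(-c3ncccc3C#N)cc2)cc1` gives 13 nM, the highest number of the three, close to compound 1 but far from compound 2. Going by the values given here, the one measured step, a 13-fold higher number from compound 2 to compound 3 (1.11 log units; beyond the scatter), shows that a swap at this spot on the ring can move the number a long way. Compound 4 `CCS(=O)(=O)Nc1cccnc1-c1ccc(C(=O)Nc2ccc(C(C)(C)C)cc2)cc1` differs from compound 3 by (ethylsulfonyl)amino in place of cyano on an aromatic carbon. Among the compounds with values here, only the step from compound 2 to compound 3 bears on this change, and it was large; the entering group has not been measured here, so the size of the coming step is uncertain. The expectation for compound 4 is a step of about a 1.5-fold higher number from compound 3 to compound 4 (0.19 log units; within the scatter), with the number estimated at 20 nM within a range from 4 nM to 100 nM.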

Compound 4, half-maximal inhibitory concentration: 4 nM
For compound 4 the middle estimate is 5.0-fold (0.70 log units) above the measured one; measured number inside the range.
By their numbers in this assay, from the lowest: compound 2; then compound 4; then compounds 1 and 3 (each within the scatter of the next).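

Position two atoms from the ring nitrogen tolerates a much bulkier replacement for the nitrile: (ethylsulfonyl)amino gives a 3.3-fold lower number from compound 3 to compound 4 (0.51 log units; beyond the scatter). Fluoro still gives the lowest number of the three, with a 4.0-fold higher number from compound 2 to compound 4 (0.60 log units; beyond the scatter), so among compounds 2, 3 and 4 the number does not simply rise with the number of heavy atoms in the group on this carbon.

From the compounds shown here alone, whether a plain amine or a methyl in place of the ethyl chain would fit this order remains open. Nothing available here explains these differences.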